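The source may report more compounds than this note shows. Statements on the series, on what has been measured and on what is new or still open speak of the compounds shown alone.

Working notes on the series. For the measured compounds named here, in a functional assay on ACHN cells (Homo sapiens) for inhibition (a higher number here means a weaker inhibitor of growth, a lower number a stronger inhibitor of growth), compound 1 `NS(=O)(=O)c1ccc(/C=C/c2ccc(O)c(O)c2)cc1` gives 20400 nM and holds the higher of the two numbers so far. Compound 2 `COc1cccc(/C=C/c2ccc(S(N)(=O)=O)cc2)c1` gives 7120 nM and lies lower by more than the scatter. Compound 3 `NS(=O)(=O)c1ccc(/C=C/c2ccc(O)cc2)cc1` is not yet measured and differs from compound 1 by hydrogen in place of hydroxy on an aromatic carbon. Going by the values given here, no measured step covers this change, so the only guide is the lower number of compound 2 (7120 nM). A modest drop in this assay is expected, slightly beyond the scatter, and the estimated step is a 2.3-fold lower number from compound 1 to compound 3 (0.36 log units; beyond the scatter) for now. For compound 3 the expected value is 9000 nM (estimated range 3000 nM to 25000 nM).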

Compound 3, concentration for 50% growth inhibition: 2280 nM
Compound 3: middle estimate off by 3.9-fold (0.60 log units), on the high side; the whole stated range lies above it.
By their numbers in this assay, from the lowest: compound 3; then compound 2; then compound 1.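

In this assay, hydrogen in place of hydroxy on this aromatic carbon, meta to a large group and ortho to a hydroxy group, gives an 8.9-fold lower number from compound 1 to compound 3 (0.95 log units; beyond the scatter). For the compounds shown here, this hydroxy is therefore not needed for growth inhibition here, and the single remaining hydroxy of compound 3 is enough to give the lowest number so far. Nothing available explains the size of this step.

Going by these compounds, whether an amine or a fluorine on this carbon would match hydrogen remains open. On these data alone, the contribution of the hydroxy retained in compound 3 also remains open.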